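Benzylamide to pyrrolidine amide: expected cell tolerance

This account rests on a few compounds, and the source may have more. Where it says the series, first, only, none or still open, it means among the compounds named here.

Measured compounds:
compound 1, `O=c1nc(N2CCN(Cc3ccncc3)CC2)sc2c([N+](=O)[O-])cc(C(F)(F)F)cc12`, > 111000 nM
compound 2, `O=C(CN1CCN(c2nc(=O)c3cc(C(F)(F)F)cc([N+](=O)[O-])c3s2)CC1)NCc1ccccc1`, 57100 nM

In a toxicity assay on HeLa cells (Homo sapiens) for cytotoxicity, read by colorimetric assay, with a stated time of 72 h (a lower number here means that less compound is tolerated, a higher number that more compound is tolerated), compound 1 gives only a limit, > 111000 nM. In this assay compound 2 gives 57100 nM. For the measured compounds named here, the single measured step, an at least 1.9-fold lower number from compound 1 to compound 2 (0.28 log units; that floor lies within the scatter), concerns a change on a saturated chain carbon bound to an amine nitrogen in a ring, and it starts from a limit, so its true size is unknown. Compound 2 thus holds the only number shown, since the other value is a limit (the limit of > 111000 nM in this assay, at which 1 of the 2 values shown sits).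

Compound 3, `O=C(CN1CCN(c2nc(=O)c3cc(C(F)(F)F)cc([N+](=O)[O-])c3s2)CC1)N1CCCC1`, differs from compound 2 by pyrrolidin-1-yl in place of benzylamino on a carbonyl carbon. Going by the values given here, no measured step touches this carbonyl carbon, and the one step available starts from a limit. Nothing therefore points to a step beyond the scatter. Compound 3 is expected to give about 57000 nM in this assay, within 20000 nM to 160000 nM, which means an estimated step of a 1.0-fold lower number from compound 2 to compound 3 (0.00 log units; within the scatter).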

Compound 3, half-maximal cytotoxic concentration: > 106000 nM
Compound 3 gave a limit, no number (the forecaster's own chance of this, stated with the estimate: 25%); middle value at least 1.8-fold (0.26 log units) away from the limit.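

In this assay compound 3 gives > 106000 nM, which is a limit and not a number. The change on the carbonyl carbon now has a step of its own, an at least 1.8-fold higher number from compound 2 to compound 3 (0.26 log units; that floor lies within the scatter), so the exchange of benzylamino for pyrrolidin-1-yl is not shown to go beyond the scatter, and its true size remains unknown. The step between compound 1 and compound 3 cannot be read, because both of its ends are limits: the limit of > 106000 nM in this assay, at which 1 of the 3 values shown sits.

The compounds shown leave open how far the true value of compound 3 lies from that of compound 2. On these data alone, how a dimethylamino group or a morpholin-4-yl ring on this carbonyl carbon would read in this assay also remains open.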